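A Fluorine Added to the Core of Compound 1

The source may hold more compounds than are shown below. What is called first, only, known or untested is meant among the compounds shown, and "the series" means these compounds.

Of the compounds shown here, three have so far been measured in an ADME assay on RAW264.7 cells (Mus musculus) for cytotoxicity, read by MTT assay, with a stated time of 24 h; a lower number here means that less compound is tolerated, a higher number that more compound is tolerated. Compound 1 `O=c1oc2ccccc2c(=O)n1-c1ccc(Cl)cc1F` gives 24400 nM. Compound 2 `O=C(Nc1ccc(Cl)cc1F)c1cc(Cl)ccc1O`, in which the fused core is opened into an amide, gives 8000 nM, and compound 3 `O=C(Nc1ccc(I)cc1F)c1cc(Cl)ccc1O` gives 7600 nM. Among these three numbers compound 1 stands highest, so it is the compound of which the most is tolerated, and its gap to compound 2 as well as to compound 3 lies beyond the scatter of this assay.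

Among the measured compounds shown here, only one pair of measured compounds differs in a single place: a 1.1-fold lower number from compound 2 to compound 3 (0.02 log units; within the scatter). That swap sits on the ring attached to the nitrogen, not on the core, and it changed the number by less than the scatter.

Compound 4 `O=c1oc2ccc(F)cc2c(=O)n1-c1ccc(Cl)cc1F` differs from compound 1 by fluoro in place of hydrogen on an aromatic carbon. For the measured compounds named here, no measured step adds a fluoro to the core, so there is no direct precedent. Going by the values given here, the one step that exists, a halogen swap on the other ring, moved nothing beyond the scatter. The step expected here is therefore a 1.0-fold lower number from compound 1 to compound 4 (0.01 log units; within the scatter), a change within the scatter. Compound 4 is expected to give about 24000 nM, with a likely range from 12000 nM to 48000 nM.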

Compound 4, half-maximal cytotoxic concentration: 7900 nM
For compound 4 the middle estimate is 3.0-fold (0.48 log units) above the measured one; measured number below the stated range.
By their numbers in this assay, from the lowest: compounds 3, 4 and 2 (each within the scatter of the next); then compound 1.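

Replacing hydrogen with fluoro on this aromatic carbon of the core gives a 3.1-fold lower number from compound 1 to compound 4 (0.49 log units; beyond the scatter) in this assay. Among the compounds shown here, this is the first single-place step on the core of compound 1, and unlike the earlier halogen swap on the ring attached to the nitrogen, it lies beyond the scatter. It shows that adding one heavy atom at this position can be enough to lower the amount of compound tolerated, although this single pair speaks only for this position and this fluoro, not for the core as a whole.

No available measurement bears on the cause of this drop.

As far as these compounds go, it also remains open whether another group on the same carbon, such as a methoxy group or an amine, would lower the number as well, whether fluoro on a different carbon of the core would do the same, and whether the same fluoro would have a similar effect on the opened amide form seen in compound 2.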